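Hydroxyalkyl amide in place of the ethoxyphenyl anilide

The source may hold more compounds than are shown below. What is called first, only, known or untested is meant among the compounds shown, and "the series" means these compounds.

The series shares one core carrying an amide at the carbonyl carbon, and the amide substituent is the only thing varied. Compound 1 `CCn1c(C(=O)N(CCC#N)CCC#N)ccc1C(CC)(CC)c1ccc(OCCC(O)(CC)CC)c(C)c1` carries two cyanoethyl chains on the amide nitrogen; in an ADME assay on L02 cells (Homo sapiens) for antiproliferative activity, read by MTT assay, with a stated time of 48 h (a higher number here means a weaker inhibitor, a lower number a stronger inhibitor), compound 1 gives 37800 nM. Compound 3 `CCOC(=O)C(CC(=O)OC)NC(=O)c1ccc(C(CC)(CC)c2ccc(OCCC(O)(CC)CC)c(C)c2)n1CC` carries a diester-bearing chain there and in this assay compound 3 gives 4280 nM. Compound 2 `CCOc1ccc(NC(=O)c2ccc(C(CC)(CC)c3ccc(OCCC(O)(CC)CC)c(C)c3)n2CC)cc1` is the anilide. For compound 2 this assay reports only a limit, > 50000 nM, so compound 2 sits at the upper edge of the numbers shown, with the weakest reading of the three; one of the three values rests at that limit (the limit of > 50000 nM in this assay, at which 1 of the 3 values shown sits).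

Compound 4 `CCn1c(C(=O)NC(C)CO)ccc1C(CC)(CC)c1ccc(OCCC(O)(CC)CC)c(C)c1` differs from compound 2 by 1-(hydroxymethyl)ethyl in place of 4-ethoxyphenyl on an amide-type nitrogen. The closest measured step is the one that also removes the 4-ethoxyphenyl from the amide nitrogen: an at least 11-fold lower number from compound 2 to compound 3 (1.06 log units; beyond the scatter). The step of an at least 1.3-fold higher number from compound 1 to compound 2 (0.12 log units; that floor lies within the scatter) points the same way, with the ring-bearing group giving the higher number. A lower number is therefore expected for compound 4, though the hydroxymethyl group entering is small and the size of the move is uncertain; the expected step is an at least 2.7-fold lower number from compound 2 to compound 4 (0.44 log units; beyond the scatter). The estimate for compound 4 is 18000 nM, within a range of 4000 nM to 60000 nM.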

Compound 4, half-maximal inhibitory concentration: 4840 nM
The estimate for compound 4 lay 3.7-fold (0.57 log units) above the measured number, within the range that was stated.
By their numbers in this assay, from the lowest: compounds 3 and 4 (each within the scatter of the next); then compound 1. At a limit, above all of these: compound 2.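

In this assay, 1-(hydroxymethyl)ethyl on the amide-type nitrogen reads level with the far larger diester-bearing chain, with a 1.1-fold higher number from compound 3 to compound 4 (0.05 log units; within the scatter), so the ester groups are not required to reach this level. Loss of the 4-ethoxyphenyl gives an at least 10-fold lower number from compound 2 to compound 4 (1.01 log units; beyond the scatter), and the change from the two cyanoethyl chains gives a 7.8-fold lower number from compound 1 to compound 4 (0.89 log units; beyond the scatter), so both ring-free groups on a single amide hydrogen-bearing nitrogen, in compound 3 and compound 4, sit beyond the scatter from compound 1 and compound 2. The step from compound 2 is only a floor, as compound 2 stands at a limit and not at a number: the limit of > 50000 nM in this assay, at which 1 of the 4 values shown sits.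

The compounds shown leave open whether the hydroxyl of 1-(hydroxymethyl)ethyl matters, as no comparison here separates it from the carbon chain that carries it. An isopropyl group, a longer hydroxyalkyl chain or a carboxylic acid on this nitrogen would bear on that.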